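Hydrazide series on HeLa cells: pyranone to methylimidazole swap

The source may report more compounds than this note shows. Statements on the series, on what has been measured and on what is new or still open speak of the compounds shown alone.

Two hydrazide-linked benzophenone ethers have been measured in a functional assay on HeLa cells (Homo sapiens) for cytotoxicity, read by trypan blue exclusion, with a stated time of 48 h; on this read-out higher numbers stand for weaker inhibition and lower numbers for stronger inhibition. Compound 1 `Cn1cnc(C(=O)NNC(=O)COc2c(F)cc(C(=O)c3ccc(Cl)cc3)cc2Cl)c1` gives 51600 nM. Compound 2 `Cc1ccc(C(=O)c2cc(F)c(OCC(=O)NNC(=O)c3ccc(=O)oc3)c(Cl)c2)cc1` gives 26200 nM in this assay. The two numbers lie within the usual scatter of each other, so no order between compound 1 and compound 2 can be read from them.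

Compound 3 `Cc1ccc(C(=O)c2cc(F)c(OCC(=O)NNC(=O)c3cn(C)cn3)c(Cl)c2)cc1` keeps the core of compound 2 and carries the change (a group of 6 heavy atoms (4 carbon, 2 nitrogen; one five-membered aromatic ring with 2 hetero atoms) in place of a group of 7 heavy atoms (5 carbon, 2 oxygen; one six-membered aromatic ring with 1 hetero atom), on a carbonyl carbon). For the measured compounds named here, the group that enters is the one found in compound 1, which with a different substituent on the benzoyl ring gives 51600 nM. Going by the values given here, no step between measured compounds isolates this change. Only a small shift, if any, is expected for compound 3, within the scatter: a 1.5-fold higher number from compound 2 to compound 3 (0.18 log units; within the scatter). Compound 3 is estimated at 40000 nM in this assay, with a range from 15000 nM to 110000 nM.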

Compound 3, half-maximal inhibitory concentration: 10200 nM
Compound 3: middle estimate off by 3.9-fold (0.59 log units), on the high side; the measured number lies below the stated range.
By their numbers in this assay, from the lowest: compound 3; then compounds 2 and 1 (each within the scatter of the next).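

On the carbonyl carbon whose other neighbour is the amide-type nitrogen, 1-methyl-1H-imidazol-4-yl in place of the six-membered aromatic ring gives, in this assay, a 2.6-fold lower number from compound 2 to compound 3 (0.41 log units; beyond the scatter), so the number at this position does depend on the group it carries. For the compounds shown here, with 1-methyl-1H-imidazol-4-yl held fixed, methyl in place of chloro on an aromatic carbon gives a 5.1-fold lower number from compound 1 to compound 3 (0.70 log units; beyond the scatter), the first isolated look at that substituent, and the larger of the two steps in number. No measurement at hand gives a reason for either step.

The compounds shown leave open whether a phenyl or a pyridine ring on the carbonyl carbon would match 1-methyl-1H-imidazol-4-yl, and whether methoxy or trifluoromethyl on the aromatic carbon would go beyond methyl. Each step rests on a single pair, so neither is known to hold with the other substituent changed.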